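Ethoxy homologue of compound 2: expected cytotoxicity

The source may hold more compounds than are shown below. What is called first, only, known or untested is meant among the compounds shown, and "the series" means these compounds.

Of the compounds shown here, two have been measured in a functional assay on MCF7 cells (Homo sapiens) for cytotoxicity, read by MTT assay, with a stated time of 48 h; on this read-out higher numbers stand for weaker inhibition and lower numbers for stronger inhibition. Compound 1 `O=C(Nc1ccc(Br)cc1)c1cn(-c2ccccc2)nc1-c1ccccc1` gives 5750 nM in this assay. Among the compounds with values here, compound 2 `COc1ccc(NC(=O)c2cn(-c3ccccc3)nc2-c2ccccc2)cc1` gives 1710 nM in this assay, the lowest of the two numbers; the step of a 3.4-fold lower number from compound 1 to compound 2 (0.53 log units; beyond the scatter) is the only measured step and sets compound 2 apart beyond the scatter.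

Compound 3 `CCOc1ccc(NC(=O)c2cn(-c3ccccc3)nc2-c2ccccc2)cc1` differs from compound 2 by methyl in place of hydrogen on a saturated chain carbon bound to an oxygen on an aromatic ring, read one bond further out as methoxy to ethoxy, so 4-methoxyphenyl becomes 4-ethoxyphenyl. Within the data shown here, no measured step bears directly on this change: the single step available exchanges bromo for methoxy and says nothing about lengthening the alkyl on the ether oxygen. With no evidence either way, the step is estimated at a 1.0-fold lower number from compound 2 to compound 3 (0.00 log units; within the scatter), within the scatter. Compound 3 is expected to give 1700 nM in this assay, with an estimated range from 700 nM to 4500 nM.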

Compound 3, half-maximal inhibitory concentration: 880 nM
Compound 3: the middle estimate sits 1.9-fold (0.29 log units) above what was measured; the measured number falls inside the stated range.
By their numbers in this assay, from the lowest: compounds 3 and 2 (each within the scatter of the next); then compound 1.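

Going from methoxy to ethoxy on the aromatic ring gives a 1.9-fold lower number from compound 2 to compound 3 (0.29 log units; within the scatter) in this assay, so the extra methyl on the saturated chain carbon bound to the oxygen leaves the number within the scatter of compound 2. Exchanging the bromo group for ethoxy gives a 6.5-fold lower number from compound 1 to compound 3 (0.82 log units; beyond the scatter), which makes ethoxy the second ether, after methoxy, to stand apart from compound 1 beyond the scatter. No measurement at hand speaks to the reason for these numbers.

Going by these compounds, whether a longer chain such as propoxy on the ether oxygen would stay within the scatter of compound 3 remains open, as does how a dimethylamino group in place of the ether would read. The rest of the shared core is identical in all three compounds, so nothing here speaks to changes there.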